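This account rests on a few compounds, and the source may have more. Where it says the series, first, only, none or still open, it means among the compounds named here.

Series screened in an ADME assay on C8166 cells (Homo sapiens) for cytotoxicity, read by colorimetric assay and MTT assay; a lower number here means that less compound is tolerated, a higher number that more compound is tolerated:

compound 1 `Cc1cc(S(N)(=O)=O)ccc1NC(=O)COc1ccc2ccccc2c1C(=O)c1ccccc1`: 33800 nM
compound 2 `Cc1cc(C)cc(C(=O)c2c(OCC(=O)Nc3ccc(S(N)(=O)=O)cc3C)ccc3ccccc23)c1`: 39100 nM
compound 3 `Cc1ccc(C)c(C(=O)c2c(OCC(=O)Nc3ccc(S(N)(=O)=O)cc3C)ccc3ccccc23)c1`: 47500 nM

All three compounds share one core and differ only in the aryl group on the carbonyl carbon. Compound 3 gives the highest of the three numbers in this assay, but its nearest neighbour is compound 2 with a 1.2-fold higher number from compound 2 to compound 3 (0.08 log units; within the scatter) and the furthest is compound 1 with a 1.4-fold higher number from compound 1 to compound 3 (0.15 log units; within the scatter); both steps sit inside the scatter, so no order among compounds 1, 2 and 3 can be read from these values.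

Compound 4 `Cc1cc(S(N)(=O)=O)ccc1NC(=O)COc1ccc2ccccc2c1C(=O)c1cc(Cl)cc(C#N)c1` has not yet been measured. Relative to compound 3 the change is 3-chloro-5-cyanophenyl in place of 2,5-dimethylphenyl on a carbonyl carbon. Going by the values given here, the steps that bear on this place are a 1.2-fold higher number from compound 1 to compound 2 (0.06 log units; within the scatter), a 1.4-fold higher number from compound 1 to compound 3 (0.15 log units; within the scatter) and a 1.2-fold higher number from compound 2 to compound 3 (0.08 log units; within the scatter), each within the scatter: phenyl, 3,5-dimethylphenyl and 2,5-dimethylphenyl on the carbonyl carbon gave numbers in this assay that cannot be told apart. Among the compounds with values here, no measured step introduces a chlorine or a nitrile at this place, so the new group is untested here. On the evidence of the three steps, compound 4 is expected to show a 1.2-fold lower number from compound 3 to compound 4 (0.07 log units; within the scatter), a step not beyond the scatter. The estimate for compound 4 in this assay is 40000 nM, with a range of 20000 nM to 80000 nM.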

Compound 4, half-maximal cytotoxic concentration: 49400 nM
Compound 4: the middle estimate sits 1.2-fold (0.09 log units) below what was measured, within the range that was stated.
By their numbers in this assay, from the lowest: compounds 1, 2, 3 and 4 (each within the scatter of the next).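

In this assay, the step to the 3-chloro-5-cyanophenyl group is a 1.0-fold higher number from compound 3 to compound 4 (0.02 log units; within the scatter), with a 1.3-fold higher number from compound 2 to compound 4 (0.10 log units; within the scatter) and a 1.5-fold higher number from compound 1 to compound 4 (0.16 log units; within the scatter), so the group cannot be told apart from any of the three earlier aryl groups on the carbonyl carbon. The earlier compounds shown here carried only an unsubstituted phenyl or a dimethylphenyl at this place, whereas compound 4 extends the flat picture to a ring bearing a chlorine and a nitrile, and none of the four compounds goes against it. Nothing available bears on why the number stays unchanged across these groups.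

All four groups shown at this place are six-membered aromatic rings of carbon only, so it remains open whether an amine, a carboxylic acid or a longer alkyl chain on the carbonyl carbon would give a number in this assay beyond the scatter. Every change shown also lies at this one place, which leaves open how changes elsewhere on the shared core would read.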